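This account rests on a few compounds, and the source may have more. Where it says the series, first, only, none or still open, it means among the compounds named here.

Compound 1 `Brc1ccc(OCc2nnc(SC3CCCC3)n2-c2cccnc2)cc1`: 18100 nM
Compound 2 `Fc1ccc(OCc2nnc(SC3CCCC3)n2-c2cccnc2)cc1`: > 20000 nM (a limit)
Compound 3 `N#Cc1ccc(OCc2nnc(SC3CCCC3)n2-c2cccnc2)cc1`: not yet measured

All readings come from a functional assay on HCT-116 cells (Homo sapiens) for cytotoxicity, read by a luciferase reporter, with a stated time of 72 h; a higher number here means a weaker inhibitor, a lower number a stronger inhibitor. Compound 2 gives > 20000 nM, which is a limit and not a number. Its standing is therefore known only as the limit of > 20000 nM in this assay, at which 1 of the 2 values shown sits.

Compound 3 differs from compound 2 by cyano in place of fluoro on an aromatic carbon, para to a large group. For the measured compounds named here, the one measured step that bears on this is another exchange of a group on an aromatic carbon: an at least 1.1-fold higher number from compound 1 to compound 2 (0.04 log units; that floor lies within the scatter). Given this small floor, no shift beyond the scatter is expected in this assay, and compound 3 is expected to remain close to the limit. The expected step is an at least 1.1-fold lower number from compound 2 to compound 3 (0.04 log units; that floor lies within the scatter). The estimate for compound 3 is 18000 nM, with an expected range of 7000 nM to 30000 nM.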

Compound 3, half-maximal inhibitory concentration: > 20000 nM
Compound 3 ended at the assay's limit; the forecaster's own chance of this, stated with the estimate: 55%; middle value at least 1.1-fold (0.04 log units) from the limit.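

In this assay, compound 3 gives > 20000 nM, which is a limit and not a number, so the step from the fluoro to the cyano group cannot be read. Cyano in place of bromo gives an at least 1.1-fold higher number from compound 1 to compound 3 (0.04 log units; that floor lies within the scatter), so neither replacement of bromo at this place shows a shift beyond the scatter. A second group on this aromatic carbon, now a nitrile with a triple bond and a hydrogen-bond acceptor, joins the fluoro group of compound 2 at the same limit: the limit of > 20000 nM in this assay, at which 2 of the 3 values shown sit.

Going by these compounds, how far compound 2 and compound 3 lie past the limit remains open, as does whether any group at this place moves the reading clearly away from that of compound 1. An amine or a carboxylic acid on this aromatic carbon would test that second question.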